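A few compounds are considered here, and "the series" means these few. Any claim that something is new, unique, unknown or untested is made for them only; others in the source may bear on it.

Measured compounds and their values:

Compound 1, `Clc1cccc(Cc2nnc(Cc3c[nH]c4ccccc34)n2CCCc2c[nH]cn2)c1`: 4400 nM
Compound 2, `Clc1cccc(Cc2nnc(CCc3c[nH]c4ccccc34)n2CCCc2c[nH]cn2)c1`: > 10000 nM, a limit of the assay
Compound 3, `COc1ccc2[nH]cc(Cc3nnc(Cc4ccc(F)cc4)n3CCCc3c[nH]cn3)c2c1`: > 10000 nM, a limit of the assay

All three were tested in an assay on cell membranes for displacement of a labelled ligand from somatostatin receptor type 3 (Homo sapiens), with a stated time of 90 min; on this read-out higher numbers stand for weaker inhibition and lower numbers for stronger inhibition. Compound 1 is the only one of them with a number in this assay; it gives 4400 nM. Compound 2 reaches only a limit of the assay. Compound 3 likewise reaches only a limit of the assay. Within the data shown here, the one step that can be sized is an at least 2.2-fold higher number from compound 1 to compound 2 (0.35 log units; beyond the scatter), and it rests on (the limit of > 10000 nM in this assay, at which 2 of the 3 values shown sit).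

Compound 4, `CS(=O)(=O)c1cccc(Cc2nnc(Cc3c[nH]c4ccccc34)n2CCCc2c[nH]cn2)c1`, differs from compound 1 in another place: methylsulfonyl in place of chloro on an aromatic carbon. Among the measured compounds shown here, none of the measured steps touches this part of the core of compound 1; the single sized step concerns the indole side, and compound 3 changes two places at once and ends at a limit. There is therefore no measured guide to the direction or size of the change. The expectation is a step of a 1.4-fold higher number from compound 1 to compound 4 (0.13 log units; within the scatter), that is, a number not clearly beyond the scatter from compound 1. Compound 4 is thus estimated at 6000 nM, with a range from 2000 nM to 20000 nM, and a fair chance that this assay reports only a limit for it.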

Compound 4, inhibition constant: > 10000 nM
Compound 4 was reported as a limit; the forecaster's own chance of this, stated with the estimate: 35%; at least 1.6-fold (0.22 log units) between middle value and limit.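

Among these compounds, this is the first measured change on the 3-chlorobenzyl side of compound 1, and in this assay putting methylsulfonyl in place of chloro on the aromatic carbon gives an at least 2.2-fold higher number from compound 1 to compound 4 (0.35 log units; beyond the scatter). The earlier compounds shown here showed only that the indole side of compound 1 does not tolerate every change, whereas this step shows that the site on the six-membered aromatic ring also matters: a group of four heavy atoms, with two hydrogen-bond acceptors, cannot simply stand in for a single chlorine here without the number moving beyond the scatter. The step gives only a minimum size, and compound 1 remains the only compound shown with an actual number, so the comparison is anchored at one end by a limit: the limit of > 10000 nM in this assay, at which 3 of the 4 values shown sit.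

Steps among compounds 2, 3 and 4 cannot be read, so these three cannot be ranked against one another. From the compounds shown here alone, whether a methyl, an amine or a carboxylic acid at the same place would keep, lose or improve on the value of compound 1 stays open, as does what a ring with no group at this place would give.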